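The source may hold more compounds than are shown below. What is called first, only, known or untested is meant among the compounds shown, and "the series" means these compounds.

In a functional assay on the whole organism (Tail, strain ICR) with Mus musculus as the target, in the tail flick test, with a stated time of 90 min, at a dose of 25 umol/kg by the oral route (a lower number here means a weaker effect, a higher number a stronger effect of the compound at the dose given), compound 2, `N=C(N)NCCC[C@H](NC(=O)CN(c1nc(Cl)nc2[nH]cnc12)C1CC1)C(=O)OCc1ccccc1`, gives 30.4%. For the measured compounds named here, of the two numbers measured so far this is the lower one; the other belongs to compound 1, `CC(C)[C@H](NC(=O)CN(c1nc(Cl)nc2[nH]cnc12)C1CC1)C(=O)OCc1ccccc1`, which in this assay gives 51.3%, so compound 2 sits at the bottom, with the step of a number 20.9 percentage points lower from compound 1 to compound 2 (beyond the scatter) lying beyond the scatter.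

Compound 3, `O=C(CN(c1nc(Cl)nc2[nH]cnc12)C1CC1)N[C@@H](CCC(=O)OCc1ccccc1)C(=O)OCc1ccccc1`, has not yet been measured. It differs from compound 2 by a group of 10 heavy atoms (8 carbon, 2 oxygen; one six-membered aromatic ring of carbon only) in place of a group of 5 heavy atoms (2 carbon, 3 nitrogen; no ring), on a saturated chain carbon, three bonds along the chain from an amide-type nitrogen and a carbonyl carbon.

Going by the values given here, only one measured step bears on this change, the one already named: a number 20.9 percentage points lower from compound 1 to compound 2 (beyond the scatter). That step brought in the very side chain whose end now leaves, and it cost activity. Among the compounds with values here, removing that end again, even though the larger benzyloxycarbonyl enters in its place, is expected to give back part of what was lost, so a step of a number 11.6 percentage points higher from compound 2 to compound 3 (beyond the scatter) upward is expected in this assay, though with only one comparison to rest on the range must be wide. Compound 3 is therefore estimated at 42%, somewhere between 22% and 62%.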

Compound 3, a percentage reported as activity, at one dose (the size of the read-out at that dose, not a potency): 50%
Compound 3: the middle estimate sits 8 percentage points below what was measured; the range from low to high includes it.
By their numbers in this assay, from the lowest: compound 2; then compounds 3 and 1 (each within the scatter of the next).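

In this assay, this position accepts a much larger side chain than the isopropyl of compound 1: with 2-(benzyloxycarbonyl)ethyl in its place, the step is a number 1.3 percentage points lower from compound 1 to compound 3 (within the scatter), so the read-out does not separate these two groups. Changing only the end of the side chain, with benzyloxycarbonyl entering and the group of 5 heavy atoms with its 3 nitrogens leaving, gives a number 19.6 percentage points higher from compound 2 to compound 3 (beyond the scatter), which shows that the drop at compound 2 does not simply follow from a bigger group, as here the bigger group goes with the higher number. Nothing available explains why the end of the chain matters in this way.

From the compounds shown here alone, what stays open is which part of benzyloxycarbonyl goes with the higher number, since a carboxylic acid or a primary amine at the end of the same chain would separate the benzyl ester from the simple absence of the nitrogen-rich end. A longer chain carrying the same benzyl ester would in turn show how far from the core that end can sit.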